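Adding a Chloro Group to a Second Core: Expected Half-Life

The compounds below may be only part of what the source reports. "The series", "measured", "known", "first", "only" and "open" are said of these compounds alone.

Three compounds have already been measured in an ADME assay on microsomes from liver (Homo sapiens) for metabolic stability, read by LC-MS, using NADPH, tested at 5 uM; a lower number here means that the compound disappears faster, a higher number that the compound lasts longer:

Compound 1 `Cc1cc(S(=O)(=O)/N=C(\N)n2nccc2-c2ccccc2)c(SCc2cccc(Cl)c2)cc1Cl` gives 0.309 h.
Compound 2 `Cc1cc(S(=O)(=O)/N=C(\N)n2nccc2-c2ccccc2)c(SCc2ccccc2)cc1Cl` gives 0.0772 h.
Compound 3 `Cc1cc(-c2ccccc2)n(/C(N)=N/S(=O)(=O)c2cc(C)c(Cl)cc2SCc2ccccc2)n1` gives 0.0938 h.

The change from compound 2 to compound 1 is chloro in place of hydrogen on an aromatic carbon, and it produced a 4.0-fold higher number from compound 2 to compound 1 (0.60 log units; beyond the scatter). Compound 3 carries a different core: it differs from compound 2 by methyl in place of hydrogen on an aromatic carbon, a change that gave a 1.2-fold higher number from compound 2 to compound 3 (0.08 log units; within the scatter).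

Compound 4 `Cc1cc(-c2ccccc2)n(/C(N)=N/S(=O)(=O)c2cc(C)c(Cl)cc2SCc2cccc(Cl)c2)n1` has not yet been measured in this assay. Within the data shown here, it differs from compound 3 by chloro in place of hydrogen on an aromatic carbon, which is the same change as the one from compound 2 to compound 1, at a place described in identical words. The expected step is a 3.5-fold higher number from compound 3 to compound 4 (0.55 log units; beyond the scatter), resting on a 4.0-fold higher number from compound 2 to compound 1 (0.60 log units; beyond the scatter) and on the closeness of the two cores seen in a 1.2-fold higher number from compound 2 to compound 3 (0.08 log units; within the scatter). Since this rests on a single earlier instance of the change, the range is kept wide. Compound 4 is therefore estimated to give 0.33 h in this assay, most likely between 0.13 h and 0.8 h.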

Compound 4, half-life: 0.205 h
For compound 4 the middle estimate is 1.6-fold (0.21 log units) above the measured one; the measured number falls inside the stated range.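

In this assay the chloro group again goes with a longer half-life on the second core, giving a 2.2-fold higher number from compound 3 to compound 4 (0.34 log units; beyond the scatter), and this step agrees with the earlier one on the first core: the same change on two cores in this assay, a 4.0-fold higher number (0.60 log units; beyond the scatter) from compound 2 to compound 1 and a 2.2-fold higher number (0.34 log units; beyond the scatter) from compound 3 to compound 4, 1.8-fold (0.26 log units) apart, within the scatter of two such steps. The methyl change that separates the two cores also behaves alike with or without the chloro group, giving a 1.5-fold lower number from compound 1 to compound 4 (0.18 log units; within the scatter), a step that agrees with its earlier counterpart: the same change on two cores in this assay, a 1.2-fold higher number (0.08 log units; within the scatter) from compound 2 to compound 3 and a 1.5-fold lower number (0.18 log units; within the scatter) from compound 1 to compound 4, 1.8-fold (0.26 log units) apart, within the scatter of two such steps. Together these results show that, across these four compounds, the gain from the chloro group carries over from one core to the other, but they rest on just two pairs and show neither how the change would behave on any other core nor why the half-life moves.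

Still open, on these data alone, is whether a fluoro, methoxy or nitrile group at the same place would go with a similar half-life. Also open, as far as these compounds go, is how the half-life would respond if the benzylsulfanyl group gave way to an amine or a longer chain.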